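The source may report more compounds than this note shows. Statements on the series, on what has been measured and on what is new or still open speak of the compounds shown alone.

Of the compounds shown here, three that share a common core have so far been measured in an assay for inhibition of Polyunsaturated fatty acid 5-lipoxygenase (Homo sapiens), read by spectrophotometry, tested at 20 uM; on this read-out higher numbers stand for more inhibition at the one concentration tested (going by the name of the read-out) and lower numbers for less inhibition. Compound 1 `COc1ccc(/C=C/C=C/C(=O)N2CCCCC2)c(OC)c1OC` gives 36% in this assay. Compound 2 `COc1cc(/C=C/C=C/C(=O)N2CCCCC2)cc(OC)c1OC` gives 66.7% in this assay. Compound 3 `COc1cc(/C=C/C=C/C(=O)N2CCCCC2)ccc1O` gives 55.5% in this assay. Among the three numbers, compound 3 stands second highest: compound 2 lies above it by a margin beyond the usual scatter, and compound 1 lies below it by a wider margin, also beyond the scatter. Among the measured compounds shown here, no two of these measured compounds differ in only one place, so no single structural step with a known effect can be read off from them.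

Compound 4 `COc1ccc(/C=C/C=C/C(=O)N2CCCCC2)cc1OC` has not yet been measured in this assay. It differs from compound 3 in one place: methyl in place of hydrogen on an oxygen on an aromatic ring. Cut one bond further out, the same change reads hydroxy to methoxy.

For the measured compounds named here, with no comparable step among the measured compounds, any expectation for compound 4 rests on loose ground. Compound 4 is expected to give about 55% in this assay, within a range from 35% to 75%. The expected step of a number 0.5 percentage points lower from compound 3 to compound 4 (within the scatter) is accordingly estimated to have no clear direction and not to exceed the usual scatter.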

Compound 4, a percentage reported as inhibition, at one concentration (the size of the read-out at that concentration, not a potency): 51.9%
The estimate for compound 4 lay 3.1 percentage points above the measured number, and the stated range covers the measured number.
By their numbers in this assay, from the lowest: compound 1; then compounds 4 and 3 (each within the scatter of the next); then compound 2.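

In this assay, swapping the hydrogen on that oxygen for methyl, which turns hydroxy into methoxy, gives a number 3.6 percentage points lower from compound 3 to compound 4 (within the scatter) and so leaves no change that can be told apart from ordinary repeat variation; at this position, a free hydroxy and a methoxy cannot be distinguished by this measurement. Compound 4 also connects the two earlier compounds that could not be compared directly, and it shows that the same kind of change, hydrogen in place of methoxy on an aromatic carbon, can point in opposite directions: the result is a number 14.8 percentage points lower from compound 2 to compound 4 (beyond the scatter) in one case but a number 15.9 percentage points higher from compound 1 to compound 4 (beyond the scatter) in the other, so the outcome of removing a methoxy depends on which pair of compounds is considered, although both steps are modest. Nothing at hand explains why these steps differ in direction or why the hydroxy to methoxy step is so small.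

On these data alone, it remains open whether this position would accept something larger or different on the oxygen, such as a longer chain, or whether an amine or a carboxylic acid in place of the hydroxy would behave the same way. Each compound also has a reading at only one concentration, so these numbers give the size of the inhibition at that concentration rather than a potency.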